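Diaryl diyne alcohols: methoxy to trifluoromethyl

The source may hold more compounds than are shown below. What is called first, only, known or untested is meant among the compounds shown, and "the series" means these compounds.

Measured compounds:
compound 1 `OCC#Cc1ccccc1C#Cc1ccccc1` with 14900 nM
compound 2 `COc1ccccc1C#Cc1ccccc1C#CCCCCO` with 14300 nM

In a functional assay on DU-145 cells (Homo sapiens) for cytotoxicity (a lower number here means a stronger inhibitor of growth, a higher number a weaker inhibitor of growth), compound 1 gives 14900 nM, while compound 2 gives 14300 nM. Within the data shown here, compound 2 carries the lowest of the two numbers, but its only neighbour is compound 1, and the two values lie within the scatter, so no order between them can be read.

Compound 3 `OCCCCC#Cc1ccccc1C#Cc1ccccc1C(F)(F)F` differs from compound 2 by trifluoromethyl in place of methoxy on an aromatic carbon. Among the measured compounds shown here, no measured pair shows a step of this kind, so no direction is expected beyond the scatter. Compound 3 is estimated at 13000 nM, range 5000 nM to 35000 nM, the expected step being a 1.1-fold lower number from compound 2 to compound 3 (0.04 log units; within the scatter).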

Compound 3, concentration for 50% growth inhibition: 6100 nM
Beside the measured number, compound 3's estimate is 2.1-fold (0.33 log units) above it; the measured number falls inside the stated range.
By their numbers in this assay, from the lowest: compound 3; then compounds 2 and 1 (each within the scatter of the next).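

In this assay, among these compounds, trifluoromethyl in place of methoxy on an aromatic carbon, ortho to a large group, gives a 2.3-fold lower number from compound 2 to compound 3 (0.37 log units; beyond the scatter) and forms the first step beyond the scatter. This position therefore registers a change of substituent, though the step is modest and rests on a single pair. No measurement on hand explains the difference.

Still open, going by these compounds, is whether a fluorine, a nitrile or an amine at this place would follow trifluoromethyl or methoxy. On these data alone, it is also open whether the step would persist with a chain of another length carrying the alcohol.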